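Swapping the Amide Ring in a Phosphodiesterase Inhibitor

The compounds below may be only part of what the source reports. "The series", "measured", "known", "first", "only" and "open" are said of these compounds alone.

For the measured compounds named here, compound 1 `COc1ccc(C(=O)Nc2ccccc2Br)cc1OC1CCCC1` was tested in an assay on isolated protein for inhibition of phosphodiesterase 4A (Sus scrofa) (a higher number here means a weaker inhibitor, a lower number a stronger inhibitor), where compound 1 gives 130 nM, the highest of the two numbers known. Compound 2 `COc1ccc(C(=O)Nc2c(Cl)cccc2Cl)cc1OC1CC2CCC1C2` gives 10 nM in this assay, a gap beyond the usual scatter. Compound 3 `COc1ccc(C(=O)NN2C(Cl)=NC=CC2Cl)cc1OC1CCCC1` has not been measured. It differs from compound 1 in one place: a group of 8 heavy atoms (4 carbon, 2 nitrogen, 2 chlorine; one six-membered non-aromatic ring with 2 hetero atoms) in place of a group of 7 heavy atoms (6 carbon, 1 bromine; one six-membered aromatic ring of carbon only), on an amide-type nitrogen. Going by the values given here, no measured pair shows this change, so only an expectation is possible: the step is expected to go toward a higher number, a weaker inhibitor, with an estimated step of a 4.6-fold higher number from compound 1 to compound 3 (0.66 log units; beyond the scatter) in this assay. Compound 3 is estimated at 600 nM, within a range from 120 nM to 3000 nM.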

Compound 3, half-maximal inhibitory concentration: 400 nM
For compound 3 the middle estimate is 1.5-fold (0.18 log units) above the measured one, within the range that was stated.
By their numbers in this assay, from the lowest: compound 2; then compound 1; then compound 3.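

Putting the new ring on the amide-type nitrogen in place of 2-bromophenyl gives a 3.1-fold higher number from compound 1 to compound 3 (0.49 log units; beyond the scatter) in this assay, a modest step. For the compounds shown here, this is the first step here in which a single place changes, as compound 1 and compound 2 differ in more than one. It shows that this place can hold a non-aromatic ring with hetero atoms and still give a measurable inhibitor, though a weaker one. Nothing measured here bears on the reason for this step. Still open, going by these compounds, is whether the chlorines or the ring itself carry the step, and how a plain piperidine ring would compare.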